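A few compounds are considered here, and "the series" means these few. Any claim that something is new, unique, unknown or untested is made for them only; others in the source may bear on it.

Measured in a functional assay on HeLa cells (Homo sapiens) for inhibition, read by MTT assay, with a stated time of 48 h; on this read-out higher numbers stand for weaker inhibition and lower numbers for stronger inhibition:
Compound 1 `O=C(CC(c1ccc(Cl)cc1)C(C(=O)Nc1ccccn1)C(=O)Nc1ccccn1)c1ccccc1`: 13600 nM
Compound 2 `O=C(CC(c1ccccc1)C(C(=O)Nc1ccccn1)C(=O)Nc1ccccn1)c1ccc(F)cc1`: "not active" (no number reported)

Among the compounds with values here, compound 1 holds the only number in this small set, since compound 2 was reported as "not active" (no number reported). Compound 3 `O=C(CC(c1ccc(Cl)cc1Cl)C(C(=O)Nc1ccccn1)C(=O)Nc1ccccn1)c1ccccc1` keeps the core of compound 1 and takes chloro in place of hydrogen on an aromatic carbon, ortho to a large group and meta to a chloro group, turning 4-chlorophenyl to 2,4-dichlorophenyl: chloro in place of hydrogen on an aromatic carbon. Within the data shown here, no measured step in this assay bears on this change, so little movement beyond the usual scatter is expected, if anything towards stronger inhibition. The expected step is a 1.4-fold lower number from compound 1 to compound 3 (0.13 log units; within the scatter). For compound 3 the estimate is 10000 nM, with a range of 4000 nM to 30000 nM.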

Compound 3, half-maximal inhibitory concentration: 13500 nM
Compound 3: middle estimate off by 1.4-fold (0.13 log units), on the low side, within the range that was stated.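

Turning the 4-chlorophenyl of compound 1 into the 2,4-dichlorophenyl of compound 3 gave a first reading on this position in this assay (a 1.0-fold lower number from compound 1 to compound 3 (0.00 log units; within the scatter)). A chloro group ortho to a large group was therefore tolerated, with the read-out staying within the scatter. No measurement available here accounts for this result.

Going by these compounds, whether a methoxy group or an amine at the same position would behave like chloro remains open. So does the role of the 4-chloro group itself, as compound 2 differs from compound 1 in more than one place.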